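A few compounds are considered here, and "the series" means these few. Any claim that something is new, unique, unknown or untested is made for them only; others in the source may bear on it.

Three compounds share one core and differ only in the group attached to the oxygen on the aromatic ring. In a functional assay on DLD-1 cells (Homo sapiens) for cytotoxicity, read by MTT assay, with a stated time of 48 h (on this read-out higher numbers stand for weaker inhibition and lower numbers for stronger inhibition), compound 1 `CCCCCCCCOc1ccc2c(Cl)ccnc2c1` gives 4500 nM; compound 2 `CCOc1ccc2c(Cl)ccnc2c1` gives 2750 nM; compound 3 `Clc1ccnc2cc(OCCCc3ccccc3)ccc12` gives 2140 nM. Compound 3 holds the lowest of the three numbers, yet its gap to compound 2 lies within the scatter, and only the gap to compound 1 is beyond it, as a 2.1-fold lower number from compound 1 to compound 3 (0.32 log units; beyond the scatter) shows.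

Compound 4 `Clc1ccnc2cc(OCCc3ccccc3)ccc12` has not been measured. It differs from compound 3 by phenyl in place of benzyl on a saturated chain carbon, two bonds along the chain from an oxygen on an aromatic ring, so the ring sits on a shorter chain. Every measured step also reworked this chain: a 1.6-fold lower number from compound 1 to compound 2 (0.21 log units; within the scatter) and a 1.3-fold lower number from compound 2 to compound 3 (0.11 log units; within the scatter) stayed within the scatter, and a 2.1-fold lower number from compound 1 to compound 3 (0.32 log units; beyond the scatter) was only modest. Changes of this kind have shifted this assay little. The expected step is therefore a 1.1-fold lower number from compound 3 to compound 4 (0.03 log units; within the scatter), not beyond the scatter. The estimate for compound 4 is 2000 nM, within a range of 1000 nM to 4200 nM.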

Compound 4, half-maximal inhibitory concentration: 3380 nM
Compound 4: the middle estimate sits 1.7-fold (0.23 log units) below what was measured; the range from low to high includes it.
By their numbers in this assay, from the lowest: compounds 3, 2, 4 and 1 (each within the scatter of the next, the first and the last beyond it).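

Trading benzyl for phenyl on this saturated chain carbon gives a 1.6-fold higher number from compound 3 to compound 4 (0.20 log units; within the scatter) in this assay and so does not separate the two ring-bearing compounds. Compound 4 also cannot be told apart from the two compounds without that ring: a 1.2-fold higher number from compound 2 to compound 4 (0.09 log units; within the scatter) and a 1.3-fold lower number from compound 1 to compound 4 (0.12 log units; within the scatter) leave it within the scatter of both, whereas the gap from compound 1 to compound 3 was beyond the scatter, so that single gap does not carry over to every compound bearing the ring. Nothing shown here gives a reason for these small differences.

These compounds leave open whether any group on this chain can move the number well beyond the scatter. An amine or a carboxylic acid at the end of the chain would test this, since all the groups shown contain only carbon and hydrogen.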